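The source may hold more compounds than are shown below. What is called first, only, known or untested is meant among the compounds shown, and "the series" means these compounds.

In a functional assay, read by spectrophotometry, with a stated time of 5 min (on this read-out lower numbers stand for stronger inhibition and higher numbers for weaker inhibition), compound 1 `CCOc1cc(/C=C/C(=O)C(=Cc2ccc(OC)c(OC)c2)C(=O)/C=C/c2ccc(O)c(OCC)c2)ccc1O` gives 11300 nM, compound 2 `CCOc1cc(C=C(C(=O)/C=C/c2ccc(O)c(OCC)c2)C(=O)/C=C/c2ccc(O)c(OCC)c2)ccc1O` gives 5140 nM and compound 3 `CCOc1cc(/C=C/C(=O)C(=Cc2ccc(O)cc2)C(=O)/C=C/c2ccc(O)c(OCC)c2)ccc1O` gives 14800 nM. Compound 3 therefore cannot be told apart from compound 1, as the data show a 1.3-fold higher number from compound 1 to compound 3 (0.12 log units; within the scatter). It does separate from compound 2, with a 2.9-fold higher number from compound 2 to compound 3 (0.46 log units; beyond the scatter).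

Compound 4 `CCOc1cc(/C=C/C(=O)C(=Cc2ccc(OCC)c(OCC)c2)C(=O)/C=C/c2ccc(O)c(OCC)c2)ccc1O` has not yet been measured, and its structure differs as follows: 3,4-diethoxyphenyl in place of 4-hydroxyphenyl on a double-bonded chain carbon bound to a double-bonded chain carbon. The most relevant evidence is a 1.3-fold higher number from compound 1 to compound 3 (0.12 log units; within the scatter), where 4-hydroxyphenyl takes the place of 3,4-dimethoxyphenyl on the same double-bonded chain carbon. That exchange does not move the number beyond the scatter. A second exchange at this place, a 2.2-fold lower number from compound 1 to compound 2 (0.34 log units; beyond the scatter), brings in 3-ethoxy-4-hydroxyphenyl and has a modest size, but that group is not the one entering here. No change beyond the scatter is therefore expected in this assay, and the estimated step is a 1.5-fold lower number from compound 3 to compound 4 (0.17 log units; within the scatter). Compound 4 is expected at 10000 nM, with an estimated range of 5000 nM to 20000 nM.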

Compound 4, half-maximal inhibitory concentration: 20200 nM
Compound 4: middle estimate off by 2.0-fold (0.31 log units), on the low side, outside the stated range (above it).
By their numbers in this assay, from the lowest: compound 2; then compounds 1, 3 and 4 (each within the scatter of the next).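

In this assay, 3,4-diethoxyphenyl in place of 4-hydroxyphenyl on a double-bonded chain carbon bound to a double-bonded chain carbon gives a step within the scatter (a 1.4-fold higher number from compound 3 to compound 4 (0.14 log units; within the scatter)), and the exchange for 3,4-dimethoxyphenyl at that place also stays within it (a 1.8-fold higher number from compound 1 to compound 4 (0.25 log units; within the scatter)). Compound 2 remains apart from this group, and ethyl in place of hydrogen on an oxygen on an aromatic ring separates it clearly from the new compound (a 3.9-fold higher number from compound 2 to compound 4 (0.59 log units; beyond the scatter)), so among these four compounds only the 3-ethoxy-4-hydroxyphenyl group gives a number that stands out. No measurement shown here accounts for this result.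

As far as these compounds go, it remains open how an amine or a carboxylic acid at this place would read out in this assay. From the compounds shown here alone, a longer chain on the oxygen is equally open.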